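From an ester-bearing side chain to a difluoro acid

The source may hold more compounds than are shown below. What is called first, only, known or untested is meant among the compounds shown, and "the series" means these compounds.

Two compounds from this series carry a measured value in a functional assay on K562 cells (Homo sapiens) for cytotoxicity, read by trypan blue exclusion, with a stated time of 96 h; on this read-out lower numbers stand for stronger inhibition and higher numbers for weaker inhibition. Compound 1 `COc1ccccc1/C=C/S(=O)(=O)Cc1ccc(OC)c([N+](=O)[O-])c1` gives 20000 nM in this assay, whereas compound 2 `COC(=O)[C@H](C)Nc1cc(CS(=O)(=O)/C=C/c2c(OC)cc(OC)cc2OC)ccc1OC` gives 200 nM, the lowest of the two numbers and a step well beyond the scatter from compound 1. Compound 2 is therefore the stronger of the pair on this read-out.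

Compound 3 `COc1cc(OC)c(/C=C/S(=O)(=O)Cc2ccc(OC)c(NC(F)(F)C(=O)O)c2)c(OC)c1` has not yet been measured. It differs from compound 2 in one place: carboxy(difluoro)methyl in place of 1-(methoxycarbonyl)ethyl on a nitrogen on an aromatic ring. The group leaving and the group entering each count the same number of heavy atoms, but the entering one brings a hydrogen-bond donor and two fluorines while losing one acceptor and the stereocentre.

Among the measured compounds shown here, no measured step of this type exists, so the expectation rests on compound 2 alone. The value for compound 3 in this assay is expected to be 600 nM, most likely between 150 nM and 3000 nM, which means an estimated step of a 3.0-fold higher number from compound 2 to compound 3 (0.48 log units; beyond the scatter) toward weaker inhibition, modest in size and close to the edge of the scatter.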

Compound 3, half-maximal inhibitory concentration: 150 nM
Compound 3: the middle estimate sits 4.0-fold (0.60 log units) above what was measured; low and high end bracket the measured number.
By their numbers in this assay, from the lowest: compounds 3 and 2 (each within the scatter of the next); then compound 1.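

In this assay, replacing 1-(methoxycarbonyl)ethyl with carboxy(difluoro)methyl on this nitrogen gives a 1.3-fold lower number from compound 2 to compound 3 (0.12 log units; within the scatter) and so shows that this position can carry two quite different side chains with no difference the assay can separate. Neither the ester nor the defined stereocentre of compound 2 is required for a number of this size, as compound 3 has neither and still reads alike. No measurement shown here explains why the two side chains read alike.

The swap changes several features at once, so the compounds shown leave open whether the acid, the two fluorines or the loss of the stereocentre matters on its own, and a carboxymethyl group, which is the same acid without the fluorines, or the methyl ester of the difluoro acid would begin to separate these features. On these data alone, it also remains open how far this tolerance extends, for instance to a plain amine with no side chain on the nitrogen or to a longer chain ending in a carboxylic acid.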